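Swapping the aryl substituent on a shared core

The source may hold more compounds than are shown below. What is called first, only, known or untested is meant among the compounds shown, and "the series" means these compounds.

Measured compounds in a functional assay on VCaP cells (Homo sapiens) for antiproliferative activity, read by CCK-8 assay, with a stated time of 6 days; a higher number here means a weaker inhibitor, a lower number a stronger inhibitor:
compound 1, `CCN(c1ccc(C#N)c(Cl)c1)c1cc(-c2ccoc2)ccc1C`, 4010 nM
compound 2, `CCN(c1ccc(C#N)c(Cl)c1)c1cc(-c2cncnc2)ccc1C`, 3920 nM
compound 3, `CCN(c1ccc(C#N)c(Cl)c1)c1cc(-c2cccnc2)ccc1C`, 1270 nM

Compound 3 gives the lowest number of the three, so it is the strongest inhibitor measured so far. Compound 4, `CCN(c1ccc(C#N)c(Cl)c1)c1cc(-n2ccnc2)ccc1C`, differs from compound 3 in one place: 1H-imidazol-1-yl in place of pyridin-3-yl on an aromatic carbon. Among the measured compounds shown here, the only steps that bear on this change are the two that alter the same group on the same aromatic carbon: a 3.2-fold lower number from compound 1 to compound 3 (0.50 log units; beyond the scatter) and a 3.1-fold lower number from compound 2 to compound 3 (0.49 log units; beyond the scatter), both modest and both running toward compound 3, while a 1.0-fold lower number from compound 1 to compound 2 (0.01 log units; within the scatter) lies within the scatter. Three different rings at this position have thus given two numbers close together and one clearly lower. For the measured compounds named here, no measured step leads to 1H-imidazol-1-yl, so the direction for compound 4 is uncertain; a modest move back toward the numbers of compound 1 and compound 2 seems about as likely as staying near compound 3. Compound 4 is therefore expected to show 2500 nM, with a range from 800 nM to 8000 nM. The expected step is a 2.0-fold higher number from compound 3 to compound 4 (0.29 log units; within the scatter).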

Compound 4, half-maximal inhibitory concentration: > 30000 nM
Compound 4: no number, only a limit; the forecaster's own chance of this, stated with the estimate: 10%; middle value at least 12-fold (1.07 log units) away from the limit.
By their numbers in this assay, from the lowest: compound 3; then compounds 2 and 1 (each within the scatter of the next). At a limit, above all of these: compound 4.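

In this assay, compound 4 gives no number, only a limit of the assay: the limit of > 30000 nM in this assay, at which 1 of the 4 values shown sits. Replacing the earlier rings with 1H-imidazol-1-yl produces an at least 23-fold higher number from compound 3 to compound 4 (1.37 log units; beyond the scatter), an at least 7.6-fold higher number from compound 2 to compound 4 (0.88 log units; beyond the scatter) and an at least 7.4-fold higher number from compound 1 to compound 4 (0.87 log units; beyond the scatter), and each of these sizes is only a minimum. The earlier compounds shown here showed this aromatic carbon carrying three different rings with measurable numbers and modest differences, whereas compound 4 shows that an aromatic ring here does not by itself preserve measurable activity in this assay.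

With a single compound of this kind, the compounds shown cannot separate the effect of the five-membered ring from that of its two hetero atoms. They also leave open how an unsubstituted phenyl ring, a simple amine or a carboxylic acid would fare on this aromatic carbon.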